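This account rests on a few compounds, and the source may have more. Where it says the series, first, only, none or still open, it means among the compounds named here.

Compound 3 `NC(=O)c1c(NC(=O)c2ccccc2Cl)sc2c1CCN(C(=S)Nc1ccccc1-c1ccccc1)C2` gives 24000 nM in a functional assay on HeLa cells (Homo sapiens) for antiproliferative activity, with a stated time of 24 h (a lower number here means a stronger inhibitor, a higher number a weaker inhibitor), the lowest of the three numbers, yet both other compounds sit within the scatter of it: compound 2 `NC(=O)c1c(NC(=O)c2ccccc2Cl)sc2c1CCN(C(=S)Nc1cccc3ccccc13)C2` gives 30800 nM and compound 1 `NC(=O)c1c(NC(=O)c2ccccc2Cl)sc2c1CCN(Cc1ccc([N+](=O)[O-])cc1)C2` gives 46100 nM. Among the measured compounds shown here, the one step that exchanges the group on the amide-type nitrogen, a 1.3-fold lower number from compound 2 to compound 3 (0.11 log units; within the scatter), lay within the scatter. Compound 4 `NC(=O)c1c(NC(=O)c2ccccc2Cl)sc2c1CCN(C(=S)Nc1cccnc1)C2` differs from compound 3 by pyridin-3-yl in place of 2-phenylphenyl on an amide-type nitrogen. For the measured compounds named here, only that small step between two aryl groups at this place bears on the change, and no pyridine at this place has been measured, so no step beyond the scatter is expected in this assay for compound 4. The expected step of a 1.3-fold higher number from compound 3 to compound 4 (0.10 log units; within the scatter) is therefore small, and compound 4 is estimated at 30000 nM, between 12000 nM and 80000 nM.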

Compound 4, half-maximal inhibitory concentration: > 50000 nM
Compound 4: only a limit was reported (the forecaster's own chance of this, stated with the estimate: 10%); middle value at least 1.6-fold (0.22 log units) away from the limit.
By their numbers in this assay, from the lowest: compounds 3, 2 and 1 (each within the scatter of the next). At a limit, above all of these: compound 4.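

In this assay compound 4 gives only a limit, > 50000 nM, and not a number. Even so, pyridin-3-yl in place of 2-phenylphenyl on an amide-type nitrogen gives an at least 2.0-fold higher number from compound 3 to compound 4 (0.31 log units; beyond the scatter), an at least modest step and the first at this place to lie beyond the scatter, so the aryl group here is not indifferent. The other two steps, an at least 1.6-fold higher number from compound 2 to compound 4 (0.21 log units; that floor lies within the scatter) and an at least 1.0-fold higher number from compound 1 to compound 4 (0.03 log units; that floor lies within the scatter), are floors only and settle nothing. As far as these compounds go, whether the loss of the second aromatic ring or the entry of the ring nitrogen carries this step stays open. A plain phenyl on the same nitrogen would separate the two.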